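The source may hold more compounds than are shown below. What is called first, only, known or untested is meant among the compounds shown, and "the series" means these compounds.

Values in a functional assay on MCF7 cells (Homo sapiens) for cytotoxicity, read by MTT assay, with a stated time of 72 h (on this read-out higher numbers stand for weaker inhibition and lower numbers for stronger inhibition), so far:
- compound 1 `O=C1C(=Cc2ccc(Br)cc2)C(=O)N(c2ccc(Cl)cc2)N1c1ccc(Cl)cc1` gives 30400 nM
- compound 2 `COc1cccc(C=C2C(=O)N(c3ccc(Cl)cc3)N(c3ccc(Cl)cc3)C2=O)c1O` gives 26700 nM
- compound 3 `O=C1C(=Cc2cccc(Cl)c2)C(=O)N(c2ccc(Cl)cc2)N1c1ccc(Cl)cc1` gives 18300 nM

Compound 3 stands level with the other two, since the steps of a 1.7-fold lower number from compound 1 to compound 3 (0.22 log units; within the scatter) and a 1.5-fold lower number from compound 2 to compound 3 (0.16 log units; within the scatter) both stay within the scatter.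

The next compound is compound 4 `COc1ccc(C=C2C(=O)N(c3ccc(Cl)cc3)N(c3ccc(Cl)cc3)C2=O)cc1OC`, and the change is 3,4-dimethoxyphenyl in place of 3-chlorophenyl on a double-bonded chain carbon bound to a double-bonded ring carbon at the same place as the earlier changes. Among the measured compounds shown here, three measured steps bear on it. For the measured compounds named here, compound 2 is the only measured compound with a methoxy group, and it is reached by a 1.1-fold lower number from compound 1 to compound 2 (0.06 log units; within the scatter) and left by a 1.5-fold lower number from compound 2 to compound 3 (0.16 log units; within the scatter), both small. Going by the values given here, with a 1.7-fold lower number from compound 1 to compound 3 (0.22 log units; within the scatter) as the third, no measured change at this place has moved the number beyond the scatter, and no compound here goes against that. No 3,4-dimethoxyphenyl compound has been measured yet, so this is only a weak guide.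

In this assay the expectation is a 1.3-fold higher number from compound 3 to compound 4 (0.12 log units; within the scatter), so no step beyond the scatter is expected.

Compound 4 is estimated at 24000 nM, with an expected range from 11000 nM to 52000 nM.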

Compound 4, half-maximal inhibitory concentration: > 128000 nM
Compound 4 gave a limit, no number; the forecaster's own chance of this, stated with the estimate: 5%; at least 5.3-fold (0.72 log units) between middle value and limit.
By their numbers in this assay, from the lowest: compounds 3, 2 and 1 (each within the scatter of the next). At a limit, above all of these: compound 4.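

The group on the double-bonded chain carbon bound to a double-bonded ring carbon can move the number beyond the scatter after all, as the 3,4-dimethoxyphenyl change shows: an at least 6.9-fold higher number from compound 3 to compound 4 (0.84 log units; beyond the scatter), an at least 4.7-fold higher number from compound 2 to compound 4 (0.68 log units; beyond the scatter) and an at least 4.2-fold higher number from compound 1 to compound 4 (0.62 log units; beyond the scatter). In this assay, going by these compounds, compound 4 gives a limit and not a number, so the true size of these steps stays unknown: the limit of > 128000 nM in this assay, at which 1 of the 4 values shown sits. Compound 2, with its 2-hydroxy-3-methoxyphenyl group, stays within the scatter of compound 1 and compound 3, so carrying a methoxy group does not by itself go with this rise.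

On these data alone, whether a single methoxy group, or an amine or a carboxylic acid in place of the methoxy groups, would give a measurable number at this place remains open. The compounds shown also leave open whether the same change behaves alike with other groups on the shared core.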